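This account rests on a few compounds, and the source may have more. Where it says the series, first, only, none or still open, it means among the compounds named here.

Measured so far:
- compound 1, `CCCn1c(=O)c2nc(-c3cnn(Cc4cc(Cl)ccc4Cl)c3)[nH]c2n(CCC)c1=O`: 190 nM
- compound 2, `CCn1c(=O)c2nc(-c3cnn(Cc4ccccc4)c3)[nH]c2n(CC)c1=O`: 580 nM
- compound 3, `CCCn1c(=O)c2nc(-c3cnn(Cc4ccc(F)c(C(F)(F)F)c4)c3)[nH]c2n(CCC)c1=O`: "not determined" (no result reported)

In an assay on CHO cells for displacement of a labelled ligand from adenosine receptor A1 (Homo sapiens) (on this read-out higher numbers stand for weaker inhibition and lower numbers for stronger inhibition), compound 2 gives 580 nM and stands highest of the two numbers in hand. Within the data shown here, the only neighbour with a number is compound 1, whose 190 nM is lower, by a gap beyond the scatter; compound 1 differs from compound 2 in several places at once, so no single change can be read from that pair. Compound 3 carries no number.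

Compound 4, `CCn1c(=O)c2nc(-c3cnn(Cc4cccc(F)c4)c3)[nH]c2n(CC)c1=O`, differs from compound 2 in one place: fluoro in place of hydrogen on an aromatic carbon. Among the measured compounds shown here, no measured pair shows this change. A small step is expected, if any, not clearly beyond the scatter and leaning toward a lower number. The step from compound 2 to compound 4 is expected to be a 1.3-fold lower number from compound 2 to compound 4 (0.11 log units; within the scatter). Compound 4 is therefore estimated at 450 nM, within 200 nM to 1000 nM.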

Compound 4, inhibition constant: 380 nM
Beside the measured number, compound 4's estimate is 1.2-fold (0.07 log units) above it, and the stated range covers the measured number.
By their numbers in this assay, from the lowest: compounds 1, 4 and 2 (each within the scatter of the next, the first and the last beyond it).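

Benzyl to 3-fluorobenzyl gives the series its first step at a single place: in this assay the change is a 1.5-fold lower number from compound 2 to compound 4 (0.18 log units; within the scatter) and so does not separate from the scatter. At this position on the aromatic ring, fluoro in place of hydrogen is thus compatible with a number close to that of the parent. Nothing available explains the size of this step.

Still open, on these data alone, is whether an amine, a methoxy group or a carboxylic acid at this position would shift the number beyond the scatter. As far as these compounds go, the effect of a butyl chain on the shared core also remains open.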